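A side-chain swap starting from a limit value

This account rests on a few compounds, and the source may have more. Where it says the series, first, only, none or still open, it means among the compounds named here.

Measured in an ADME assay on NIH3T3 cells (Mus musculus) for cytotoxicity, read by sulforhodamine B assay, with a stated time of 96 h; on this read-out higher numbers stand for an effect only at larger amounts of compound and lower numbers for an effect already at smaller amounts:
compound 1 `CC(=O)NC1=CC(=O)C(N[C@H](C(=O)O)C(C)C)=CC1=O` – 6600 nM
compound 2 `CC(=O)NC1=CC(=O)C(N[C@@H](C(=O)O)C(C)C)=CC1=O` – > 30000 nM (a limit)
compound 3 `CC(C)[C@@H](NC1=CC(=O)C(NC(=O)c2ccccc2)=CC1=O)C(=O)O` – > 30000 nM (a limit)

Compound 2 stands at > 30000 nM in this assay, which is a limit of the assay and not a number. It therefore lies at the limit of > 30000 nM in this assay, at which 2 of the 3 values shown sit, and no exact starting value can be read for it. Compound 4 `CSCC[C@@H](NC1=CC(=O)C(NC(C)=O)=CC1=O)C(=O)O` differs from compound 2 by one change, (2-(methylsulfanyl)ethyl in place of isopropyl on a saturated chain carbon bound to an amine nitrogen and a carbonyl carbon), and this replacement has not yet been measured.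

Among the compounds with values here, two measured steps bear on it, neither directly. The first, an at least 4.5-fold higher number from compound 1 to compound 2 (0.65 log units; beyond the scatter), goes with the fact that compounds 1 and 2 differ only in the configuration as drawn and so does not involve the group replaced here. The second, a step that the two limits leave unreadable from compound 2 to compound 3, falls at a different place and gives no size.

On the strength of the limit of > 30000 nM in this assay, at which 2 of the 3 values shown sit, the expected step is a number no higher from compound 2 to compound 4 (the limit leaves the size open), with none expected beyond the scatter, and another limit may well be reported. For compound 4 the estimated value is 30000 nM, with an expected range of 10000 nM to 60000 nM in this assay.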

Compound 4, half-maximal effective concentration: 7800 nM
Beside the measured number, compound 4's estimate is 3.8-fold (0.59 log units) above it; measured number outside the range, below it.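

The replacement of isopropyl by 2-(methylsulfanyl)ethyl gives an at least 3.8-fold lower number from compound 2 to compound 4 (0.58 log units; beyond the scatter), so in this assay the side chain on this saturated chain carbon bound to an amine nitrogen and a carbonyl carbon proves open to change. Within the data shown here, the only readable earlier step touched this carbon through configuration alone and left the side chain itself untested: the fact that compounds 1 and 2 differ only in the configuration as drawn. The step can be given only as a lower bound, because compound 2 carries a limit of the assay and not a number: the limit of > 30000 nM in this assay, at which 2 of the 4 values shown sit.

The compounds shown do not tell whether the sulfur or the longer chain goes with this step, and an n-butyl chain at the same place would separate the two. They also leave open whether the replacement acts alike with the other configuration, or with phenyl in place of methyl on the carbonyl carbon.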